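The compounds below may be only part of what the source reports. "The series", "measured", "known", "first", "only" and "open" are said of these compounds alone.

Compound 2 `ClCc1ccccc1Cn1cnc2ncnc(Cl)c21` gives the higher of the two numbers in a functional assay on NCI-H322M cells (Homo sapiens) for cytotoxicity, read by sulforhodamine B assay, with a stated time of 48 h (a lower number here means a stronger inhibitor of growth, a higher number a weaker inhibitor of growth), at 15800 nM. Compound 1 `ClCc1ccc(Cn2cnc3nc(Cl)nc(Cl)c32)cc1` gives 1900 nM in this assay, a lower number that lies beyond the scatter, though these two differ in more than one place. Compound 3 `ClCc1ccccc1Cn1cnc2nc(Cl)nc(Cl)c21` carries chloro in place of hydrogen on an aromatic carbon. Within the data shown here, no single-change pair here shows what this chloro alone does, so the expected step from compound 2 to compound 3 in this assay, a 3.5-fold lower number from compound 2 to compound 3 (0.55 log units; beyond the scatter), is a moderate move toward a lower number, drawn only from the dichloro compound 1 at 1900 nM. Compound 3 is accordingly estimated at 4500 nM, with a range of 1500 nM to 14000 nM.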

Compound 3, concentration for total growth inhibition: 14500 nM
The estimate for compound 3 lay 3.2-fold (0.51 log units) below the measured number, and the stated range ends below it.
By their numbers in this assay, from the lowest: compound 1; then compounds 3 and 2 (each within the scatter of the next).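

In this assay the chloro on the aromatic carbon between two ring nitrogen atoms gives a 1.1-fold lower number from compound 2 to compound 3 (0.04 log units; within the scatter) and so, in this pair, brings no measurable change in growth inhibition. The lower number of compound 1 therefore cannot be credited to this chloro on the evidence of this pair alone. Nothing at hand gives a reason for so flat a step. From the compounds shown here alone, whether an amine or a methoxy group on this same carbon would shift the number stays open. So does whether this chloro would count for more with the chloromethyl group placed as in compound 1.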